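Chain terminus variation on the shared core

The compounds below may be only part of what the source reports. "The series", "measured", "known", "first", "only" and "open" are said of these compounds alone.

Of the compounds shown here, three on the shared core have been measured so far: compound 1 `CCN(CC)C(=O)COc1ccc2c(=O)cc(-c3cc(C(C)(C)C)c(O)c(C(C)(C)C)c3)oc2c1`, compound 2 `CCCCCCOc1ccc2c(=O)cc(-c3cc(C(C)(C)C)c(O)c(C(C)(C)C)c3)oc2c1` and compound 3 `CC(C)(C)c1cc(-c2cc(=O)c3ccc(OCCO)cc3o2)cc(C(C)(C)C)c1O`. In a functional assay for inhibition (a lower number here means a stronger inhibitor, a higher number a weaker inhibitor), compound 1 gives 3000 nM, compound 2 gives 5000 nM and compound 3 gives 3000 nM. Compound 3 stands level with compound 1 at the digits reported, the two together the lowest of the three numbers; its step to compound 2, a 1.7-fold lower number from compound 2 to compound 3 (0.22 log units; within the scatter), is its largest gap and still within the scatter. The steps of a 1.7-fold higher number from compound 1 to compound 2 (0.22 log units; within the scatter) and no change at the digits printed from compound 1 to compound 3 (within the scatter) likewise stay within the scatter, so the group at the end of the chain on the aromatic oxygen has, among these three compounds, made no resolvable difference.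

Compound 4 `CC(C)(C)c1cc(-c2cc(=O)c3ccc(OCCCS(=O)(=O)O)cc3o2)cc(C(C)(C)C)c1O` carries the change (sulfomethyl in place of hydroxy on a saturated chain carbon, two bonds along the chain from an oxygen on an aromatic ring). The step that bears most directly on it is a 1.7-fold lower number from compound 2 to compound 3 (0.22 log units; within the scatter), which exchanged the same terminal position and moved nothing beyond the scatter; the other two steps point the same way. No step beyond the scatter is therefore expected in this assay, in either direction, though the entering group is larger than anything exchanged here and the range is kept wide. For compound 4 the estimate is 3000 nM, between 1000 nM and 10000 nM, a step of no change at the digits printed from compound 3 to compound 4 (within the scatter).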

Compound 4, half-maximal inhibitory concentration: 500 nM
The estimate for compound 4 lay 6.0-fold (0.78 log units) above the measured number; measured number below the stated range.
By their numbers in this assay, from the lowest: compound 4; then compounds 1, 3 and 2 (each within the scatter of the next).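

Going by these compounds alone, the 3-sulfopropoxy group is the first exchange on this chain to move the number beyond the scatter in this assay, with a 6.0-fold lower number from compound 3 to compound 4 (0.78 log units; beyond the scatter) when it replaces 2-hydroxyethoxy. The direction is the same against the other two chain ends, with a 10-fold lower number from compound 2 to compound 4 (1.00 log units; beyond the scatter) and a 6.0-fold lower number from compound 1 to compound 4 (0.78 log units; beyond the scatter), so the position that made no resolvable difference among compound 1, compound 2 and compound 3 does respond to a change, and compound 4 stands alone at the low end of the series. Nothing in the data shown accounts for this step.

The change to compound 4 exchanges the terminal hydroxy for a sulfo group and also lengthens the chain, so the compounds shown cannot assign the step to either part; a 3-hydroxypropoxy chain would separate the two, and a 2-sulfoethoxy or 4-sulfobutoxy chain would test how far the sulfo group can sit from the aromatic oxygen. As far as these compounds go, whether another terminal group, such as a carboxylic acid, a phosphonic acid or an amine, on the same chain would give a similar step also remains open.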